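The source may report more compounds than this note shows. Statements on the series, on what has been measured and on what is new or still open speak of the compounds shown alone.

Working notes on the series.

Compound 2 `O=C(/C(=C\c1ccc(Cl)cc1)S(=O)(=O)c1ccc(Br)cc1)c1ccc(Br)cc1` carries the highest number of the three measured in a functional assay on DU-145 cells (Homo sapiens) for inhibition, read by trypan blue exclusion, with a stated time of 96 h (a lower number here means a stronger inhibitor of growth, a higher number a weaker inhibitor of growth), giving 50000 nM. Compound 1 `O=C(/C(=C\c1ccc(OC(F)(F)F)cc1)S(=O)(=O)c1ccc(Br)cc1)c1ccc(Br)cc1` gives 25000 nM in this assay, and compound 3 `COc1ccc(/C=C(/Sc2ccc(F)cc2)C(=O)c2ccc(OC)cc2)cc1` gives 25000 nM; both sit within the scatter of compound 2, so no order among the three is established. Among the compounds with values here, the one measured step on this core, a 2.0-fold higher number from compound 1 to compound 2 (0.30 log units; within the scatter), exchanges one group on an aromatic carbon and stays within the scatter.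

The next compound, compound 4 `O=C(/C(=C\c1ccc(F)cc1Cl)S(=O)(=O)c1ccc(Br)cc1)c1ccc(Br)cc1`, differs from compound 2 in one place: 2-chloro-4-fluorophenyl in place of 4-chlorophenyl on a double-bonded chain carbon bound to a double-bonded chain carbon. Within the data shown here, no measured step involves a 2-chloro-4-fluorophenyl group, so the only bearing evidence is the change on this same aromatic ring, a 2.0-fold higher number from compound 1 to compound 2 (0.30 log units; within the scatter), which stayed within the scatter. Compound 4 is therefore expected to show no step beyond the scatter, a 1.3-fold lower number from compound 2 to compound 4 (0.10 log units; within the scatter). The estimate for compound 4 in this assay is 40000 nM, with a range from 15000 nM to 100000 nM.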

Compound 4, concentration for 50% growth inhibition: 50000 nM
For compound 4 the middle estimate is 1.3-fold (0.10 log units) below the measured one; low and high end bracket the measured number.
By their numbers in this assay, from the lowest: compounds 1, 3, 2 and 4 (each within the scatter of the next).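

In this assay, putting 2-chloro-4-fluorophenyl in place of 4-chlorophenyl on a double-bonded chain carbon bound to a double-bonded chain carbon gives no change at the digits printed from compound 2 to compound 4 (within the scatter). The earlier step on this ring exchanged one group for another, whereas this change takes the group from 7 to 8 heavy atoms and adds a second halogen, and the number still does not leave the scatter. Nothing available explains this result, and it supports no statement about the cause.

Every step read on this ring so far lies within the scatter, so no group here is shown to move the number in either direction. Whether an amine or a carboxylic acid on this ring would give a step beyond the scatter remains open, as does any group that would bring the number well below those of the four compounds shown.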